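The compounds below may be only part of what the source reports. "The series", "measured", "known", "first", "only" and "open" are said of these compounds alone.

Compounds measured:
compound 1 `Cc1cc(OCc2cccc(F)c2)ccc1CN1CC[C@H]1C(N)=O` — 258 nM
compound 2 `C[C@H](NCc1ccc(OCc2cccc(F)c2)cc1F)C(N)=O` — 61 nM
compound 3 `NC(=O)[C@@H]1CCN1Cc1ccc(OCc2cccc(F)c2)cc1` — 21 nM

In an assay on Sf9 cells for inhibition of Amine oxidase [flavin-containing] B (Homo sapiens), with stated times of 15 min and 60 min (a lower number here means a stronger inhibitor, a higher number a weaker inhibitor), compound 3 gives the lowest number of the three; compound 2 is nearest, compound 1 furthest. Among the compounds with values here, the only single-point step measured, a 12-fold lower number from compound 1 to compound 3 (1.09 log units; beyond the scatter), concerns loss of a methyl and does not match the change to compound 4 `NC(=O)[C@@H]1CCN1Cc1ccc(OCc2cccc(F)c2)cc1F`, which is fluoro in place of hydrogen on an aromatic carbon. Compound 2 carries a fluoro at the comparable place but also an open-chain amide, so its value and that of compound 3 show only a moderate gap, not a clean step. Within the data shown here, with no direct precedent, no step beyond the scatter is expected; the estimated step of a 1.4-fold higher number from compound 3 to compound 4 (0.15 log units; within the scatter) is small. Compound 4 is therefore expected near 30 nM, range 10 nM to 90 nM.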

Compound 4, half-maximal inhibitory concentration: 26 nM
For compound 4 the middle estimate is 1.2-fold (0.06 log units) above the measured one; measured number inside the range.
By their numbers in this assay, from the lowest: compounds 3 and 4 (each within the scatter of the next); then compound 2; then compound 1.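

In this assay, fluoro on the aromatic carbon ortho to the (2-carbamoylazetidin-1-yl)methyl group leaves the number unchanged within the scatter, with a 1.2-fold higher number from compound 3 to compound 4 (0.09 log units; within the scatter), while fluoro in place of methyl there gives a 9.9-fold lower number from compound 1 to compound 4 (1.00 log units; beyond the scatter). With the fluoro in common, 2-carbamoylazetidin-1-yl in place of (1-carbamoylethyl)amino gives a 2.3-fold lower number from compound 2 to compound 4 (0.37 log units; beyond the scatter), a single-place reading of that exchange. No available measurement bears on the reason for these steps.

Open, from the compounds shown here alone, is whether chloro or nitrile on this aromatic carbon would read like fluoro. Also open, going by these compounds, is how a carboxylic acid in place of the carbamoyl group would read.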